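A few compounds are considered here, and "the series" means these few. Any claim that something is new, unique, unknown or untested is made for them only; others in the source may bear on it.

Of the compounds shown here, two built on the same core have been measured in a functional assay on S1 cells (Homo sapiens) for cytotoxicity, read by MTT assay, with a stated time of 72 h; on this read-out higher numbers stand for weaker inhibition and lower numbers for stronger inhibition. Compound 1 `COc1cc(/C=C/c2cc(C)no2)ccc1O` carries both a methoxy group and a hydroxy group on its six-membered aromatic ring of carbon only, and in this assay compound 1 gives 50500 nM. Compound 2 `Cc1cc(/C=C/c2ccc(O)cc2)on1` keeps only the hydroxy group, and in this assay compound 2 gives 44200 nM. Removing the methoxy group thus made almost no difference: a 1.1-fold lower number from compound 1 to compound 2 (0.06 log units; within the scatter). For the measured compounds named here, on the two numbers so far, compound 2 stands lowest. The gap to compound 1 is within the scatter, so neither compound can be called the stronger.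

Compound 3 `Cc1cc(/C=C/c2ccc(O)c(O)c2)on1` is the next step from compound 2: hydroxy in place of hydrogen on an aromatic carbon. Going by the values given here, the only measured step that touches this same place on the ring is the one from compound 1 to compound 2, and it was small. Among the compounds with values here, with that as the sole guide, a modest or no change beyond the scatter is expected, and the estimated step is a 1.5-fold lower number from compound 2 to compound 3 (0.17 log units; within the scatter). For compound 3 in this assay the expected value is therefore 30000 nM, with a likely range from 10000 nM to 90000 nM.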

Compound 3, half-maximal inhibitory concentration: 7900 nM
Compound 3: middle estimate off by 3.8-fold (0.58 log units), on the high side; measured number outside the range, below it.
By their numbers in this assay, from the lowest: compound 3; then compounds 2 and 1 (each within the scatter of the next).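

In this assay, the place ortho to the existing hydroxy group turns out to respond to substitution: putting a hydroxy group there in place of hydrogen gives a 5.6-fold lower number from compound 2 to compound 3 (0.75 log units; beyond the scatter). The oxygen atom alone does not account for this, since the same place carries an oxygen in compound 1 and removing the whole methoxy group gives only a 1.1-fold lower number from compound 1 to compound 2 (0.06 log units; within the scatter), whereas removing just the methyl from that oxygen gives a 6.4-fold lower number from compound 1 to compound 3 (0.81 log units; beyond the scatter). Among these three compounds, then, only the free hydroxy group stands apart from hydrogen at this place, though no measurement here explains the difference.

The compounds shown cover only hydrogen, methoxy and hydroxy at this place, so it remains open whether an amine, a fluorine atom or a carboxylic acid there would go with a number like that of compound 3 or like that of compound 2. As far as these compounds go, it is also open whether the lower number depends on the neighbouring hydroxy group, or whether a single hydroxy group at the new place, with hydrogen at the old one, would do the same.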